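Acetylpiperazine in place of methylpiperazine on the amide carbonyl

This account rests on a few compounds, and the source may have more. Where it says the series, first, only, none or still open, it means among the compounds named here.

Measured compounds:
compound 1, `CC[C@@H]1CC[C@@H](C(=O)N2CCN(C)CC2)N1C(=O)C1=C(C(C)C)N2C(=N[C@@](C)(c3ccc(Cl)cc3)[C@H]2c2ccc(Cl)cc2)S1`, 83 nM in a functional assay on MV4-11 cells (Homo sapiens) for inhibition, read by luminescence, with a stated time of 3 days; on this read-out higher numbers stand for weaker inhibition of growth and lower numbers for stronger inhibition of growth
compound 2, `CC[C@@H]1CC[C@@H](C(=O)N2CCN(C(C)=O)[C@H](C)C2)N1C(=O)C1=C(C(C)C)N2C(=N[C@@](C)(c3ccc(Cl)cc3)[C@H]2c2ccc(Cl)cc2)S1`, 220 nM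

Compound 1 gives the lowest of the two numbers in this assay; its nearest neighbour is compound 2, and the step is a 2.7-fold higher number from compound 1 to compound 2 (0.42 log units; beyond the scatter).

Compound 3, `CC[C@@H]1CC[C@@H](C(=O)N2CCN(C(C)=O)[C@@H](C)C2)N1C(=O)C1=C(C(C)C)N2C(=N[C@@](C)(c3ccc(Cl)cc3)[C@H]2c2ccc(Cl)cc2)S1`, has not yet been measured. Its change from compound 1 is a group of 10 heavy atoms (7 carbon, 2 nitrogen, 1 oxygen; one six-membered non-aromatic ring with 2 hetero atoms) in place of a group of 7 heavy atoms (5 carbon, 2 nitrogen; one six-membered non-aromatic ring with 2 hetero atoms), on a carbonyl carbon. Compound 2 carries the same entering group in the other configuration at its one defined stereocentre, so the step to compound 2 is the only one that bears on this change, and it was a modest weakening beyond the scatter. Among the measured compounds shown here, the step to compound 3 is therefore expected to be of similar size and in the same direction, a 2.4-fold higher number from compound 1 to compound 3 (0.38 log units; beyond the scatter), since no second step separates the two configurations. Compound 3 is accordingly estimated at 200 nM, within 80 nM to 500 nM.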

Compound 3, concentration for 50% growth inhibition: 120 nM
Beside the measured number, compound 3's estimate is 1.7-fold (0.22 log units) above it, and the stated range covers the measured number.
By their numbers in this assay, from the lowest: compounds 1, 3 and 2 (each within the scatter of the next, the first and the last beyond it).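

In this assay, the same entering group in the other configuration gives a 1.4-fold higher number from compound 1 to compound 3 (0.16 log units; within the scatter), so the exchange of the 4-methylpiperazin-1-yl group on this carbonyl carbon does not carry a step beyond the scatter in both configurations, as the earlier 2.7-fold higher number from compound 1 to compound 2 (0.42 log units; beyond the scatter) alone might have suggested. The two configurations themselves are not separated, with a 1.8-fold lower number from compound 2 to compound 3 (0.26 log units; within the scatter). This is the cleanest comparison of the stereocentre in the set, and it gives no firm preference for either drawing, the pair being matched as follows: the fact that compounds 2 and 3 differ only in the configuration as drawn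

From the compounds shown here alone, it remains open whether the acetyl group or the ring methyl group matters more at this place. An acetylpiperazine without the ring methyl group, or a morpholine on the same carbonyl carbon, would test how far this tolerance extends.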